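The source may report more compounds than this note shows. Statements on the series, on what has been measured and on what is new or still open speak of the compounds shown alone.

Compound 1 `COc1ccc(-c2cnc(NC(=O)c3cccc(F)c3)n2C)cc1`: > 100000 nM
Compound 2 `COc1ccc(-c2cnc(NC(=O)C3CCCCC3)n2C)cc1`: > 100000 nM

In a toxicity assay on THP-1 cells (Homo sapiens) for inhibition (a lower number here means that less compound is tolerated, a higher number that more compound is tolerated), compound 2 gives > 100000 nM. This is a limit of the assay and not a number. It is also the only kind of result available so far: the limit of > 100000 nM in this assay, at which 2 of the 2 values shown sit.

Compound 3 `COc1ccc(-c2cnc(NC(=O)c3ccncc3)n2C)cc1` keeps the shared core and has pyridin-4-yl in place of cyclohexyl on a carbonyl carbon.

Among the compounds with values here, the one measured step that bears on this change sits at the same place: a step that the two limits leave unreadable from compound 1 to compound 2. Its size cannot be read, so it gives no measured effect to carry over. Neither the 3-fluorophenyl of compound 1 nor the cyclohexyl of compound 2 brought the result off the limit. No step beyond the scatter is therefore expected in this assay, and another limit is the likeliest report. The estimated step is a number no higher from compound 2 to compound 3 (the limit leaves the size open). Compound 3 is expected at 100000 nM, with an estimated range of 50000 nM to 200000 nM.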

Compound 3, half-maximal cytotoxic concentration: > 100000 nM
Compound 3 was reported as a limit; the forecaster's own chance of this, stated with the estimate: 85%; the middle value sits exactly at the limit.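

In this assay compound 3 gives > 100000 nM as a limit of the assay and not a number. Within the data shown here, no step among compound 1, compound 2 and compound 3 can be read: the limit of > 100000 nM in this assay, at which 3 of the 3 values shown sit. The compounds shown leave open at what concentration any of the three becomes toxic to these cells.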